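The compounds below may be only part of what the source reports. "The series", "measured", "known", "first", "only" and "open" are said of these compounds alone.

Of the compounds shown here, two of a shared core have been measured in an ADME assay on C8166 cells (Homo sapiens) for cytotoxicity, read by colorimetric assay and MTT assay; on this read-out lower numbers stand for higher toxicity in this test and higher numbers for lower toxicity in this test. Compound 1, `Cc1ccc(C(=O)c2c(OCC(=O)Nc3ccc(S(N)(=O)=O)cc3C)ccc3cc(Br)ccc23)c(C)c1`, gives 61400 nM. Compound 2, `Cc1ccc(C(=O)c2c(OCC(=O)Nc3ccc(S(N)(=O)=O)cc3C)ccc3cc(Br)ccc23)cc1C`, gives 85200 nM, the highest of the two numbers; its nearest neighbour is compound 1, and the step of a 1.4-fold higher number from compound 1 to compound 2 (0.14 log units; within the scatter) lies within the scatter, so the two values cannot be told apart.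

Compound 3, `Cc1cc(S(N)(=O)=O)ccc1NC(=O)COc1ccc2cc(Br)ccc2c1C(=O)c1cc(Cl)cc(Br)c1`, has not yet been measured. It differs from compound 2 in one place: 3-bromo-5-chlorophenyl in place of 3,4-dimethylphenyl on a carbonyl carbon. Among the measured compounds shown here, the only measured step, a 1.4-fold higher number from compound 1 to compound 2 (0.14 log units; within the scatter), also sits on the group attached to this carbonyl carbon, but it exchanges one dimethylphenyl for another and says nothing about a halogenated ring. For the measured compounds named here, no measured compound carries bromine or chlorine on this ring, so there is no step in the data that bears directly on the change.

With nothing to point in either direction, the expectation for compound 3 is a number close to that of compound 2, with the step of a 1.2-fold lower number from compound 2 to compound 3 (0.09 log units; within the scatter) estimated to stay within the scatter. The value of compound 3 in this assay is estimated at 70000 nM, with a range from 25000 nM to 200000 nM.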

Compound 3, half-maximal cytotoxic concentration: 28500 nM
For compound 3 the middle estimate is 2.5-fold (0.39 log units) above the measured one; the range from low to high includes it.
By their numbers in this assay, from the lowest: compound 3; then compounds 1 and 2 (each within the scatter of the next).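

In this assay the group on the carbonyl carbon proves able to move the number beyond the scatter: 3-bromo-5-chlorophenyl in place of 3,4-dimethylphenyl gives a 3.0-fold lower number from compound 2 to compound 3 (0.48 log units; beyond the scatter) and in place of 2,4-dimethylphenyl gives a 2.2-fold lower number from compound 1 to compound 3 (0.33 log units; beyond the scatter) so that both steps are modest but readable, whereas exchanging one dimethylphenyl for the other left two values that could not be told apart. On this read-out the shift runs toward higher toxicity in this test, which sets the compound with the halogenated ring apart from both dimethylphenyl compounds. Nothing available gives a reason for this shift.

The compounds shown leave open whether the bromine, the chlorine or the loss of the two methyl groups carries the change, since all of these come together in one step and a phenyl ring bearing chlorine alone or bromine alone would be needed to separate them. They also leave open how this position responds to quite different groups on the carbonyl carbon, such as a ring carrying an amine or a carboxylic acid, or a cyclohexyl group in place of the phenyl ring.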